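A Methyl Group Added to an Inactive Sulfone

The compounds below may be only part of what the source reports. "The series", "measured", "known", "first", "only" and "open" are said of these compounds alone.

Compound 2 `O=S(=O)(CC1=NCCO1)C1=NNCC1c1ccccc1` shows no measurable effect in a functional assay, tested at 100 ug/mL (a higher number here means a stronger effect of the compound at the concentration tested, a lower number a weaker effect), and is reported as "not active" (no number reported). Compound 3 `O=S(=O)(CC1=NCCS1)c1c(-c2ccccc2)noc1-c1ccccc1` is likewise reported in this assay as "not active" (no number reported). Compound 1 `Cc1ccc(C2CNN=C2S(=O)(=O)CC2=NCCS2)cc1`, by contrast, gives 45.1% in this assay. Compound 2 thus stands among the two compounds for which no number is given, with only compound 1 showing a measured response. Compound 4 `Cc1ccc(C2CNN=C2S(=O)(=O)CC2=NCCO2)cc1` is the compound still to be measured; it differs from compound 2 by methyl in place of hydrogen on an aromatic carbon. Going by the values given here, no measured pair shows the size of this step, and since compound 2 gave no number, the step cannot be read from the data. A modest upward shift beyond the scatter is expected, guided by compound 1 giving 45.1%. Compound 4 is therefore estimated at 25% in this assay, within 0% to 55%.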

Compound 4, a percentage reported as activity, at one concentration (the size of the read-out at that concentration, not a potency): 46.8%
Estimate against measurement, compound 4: 21.8 percentage points below, and the stated range covers the measured number.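

In this assay, the phenyl to 4-methylphenyl change separates compound 2, at "not active" (no number reported), from compound 4, at 46.8%, so the methyl marks the difference between no reported activity and a measured response, although the size of this step cannot be read. The ring on the saturated chain carbon matters little once the methyl is present: a number 1.7 percentage points higher from compound 1 to compound 4 (within the scatter), so the oxygen and sulfur rings cannot be told apart. Nothing available explains either observation. Still open, from the compounds shown here alone, is whether an ethyl, a methoxy or a chlorine in place of the methyl would give a similar response.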